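A few compounds are considered here, and "the series" means these few. Any claim that something is new, unique, unknown or untested is made for them only; others in the source may bear on it.

Measured so far, in a functional assay on HL-60 cells (Homo sapiens) for activation, read by flow cytometry, with a stated time of 4 days; on this read-out higher numbers stand for an effect only at larger amounts of compound and lower numbers for an effect already at smaller amounts:
Compound 1 `COc1ccc(-n2cnc3cnc(-c4ccc(F)cc4C)cc32)cc1` gives 6 nM.
Compound 2 `COc1ccc(-n2cnc3cnc(-c4ccc(F)cc4C)cc32)cc1Cl` gives 21 nM.

Compound 2 stands at the higher of these two numbers. Going by the values given here, its only neighbour is compound 1, and the step between them, a 3.5-fold higher number from compound 1 to compound 2 (0.54 log units; beyond the scatter), lies beyond the usual scatter; it is also the only measured comparison in the set.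

Compound 3 `COc1ccc(-n2cnc3cnc(-c4ccc(F)cc4C)cc32)cc1C(C)C` is not yet measured. It differs from compound 2 in one place: isopropyl in place of chloro on an aromatic carbon. Among the compounds with values here, the one step that bears on this change is the step just described: a modest rise in the number when a chloro group entered at the same place on the ring. Within the data shown here, no measured compound shows what an isopropyl group does there, so the expectation rests on that single step and only loosely. Given a 3.5-fold higher number from compound 1 to compound 2 (0.54 log units; beyond the scatter), a further group at this place is expected to leave the number similar or somewhat higher; the expected step is a 1.9-fold higher number from compound 2 to compound 3 (0.28 log units; within the scatter), with wide uncertainty in both directions. The estimate for compound 3 in this assay is 40 nM, between 10 nM and 160 nM.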

Compound 3, half-maximal effective concentration: > 10000 nM
Compound 3 ended at the assay's limit; the forecaster's own chance of this, stated with the estimate: 5%; middle value at least 250-fold (2.39 log units) away from the limit.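

In this assay compound 3 gives > 10000 nM, which is a limit of the assay and not a number. At this place on the ring, ortho to a methoxy group, putting isopropyl in place of chloro gives an at least 470-fold higher number from compound 2 to compound 3 (2.67 log units; beyond the scatter), and putting it in place of hydrogen gives an at least 1600-fold higher number from compound 1 to compound 3 (3.22 log units; beyond the scatter), whereas chloro in place of hydrogen gave only a 3.5-fold higher number from compound 1 to compound 2 (0.54 log units; beyond the scatter). The earlier pair suggested that this place accepts a substituent at a modest cost, but the new result shows that the outcome depends strongly on which group sits there: chloro, with 1 heavy atom, keeps a measurable effect, while isopropyl, with 3 heavy atoms, takes the read-out to the limit.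

With only hydrogen, chloro and isopropyl at this place, the compounds shown leave open whether the number climbs gradually with the count of heavy atoms or jumps suddenly, which a methyl or an ethyl group would help to separate. They also leave open whether an amine or a hydroxyl group with a similar count of heavy atoms would meet the same fate.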